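Replacing 2-(trifluoromethoxy)benzyl with cyclopropylmethyl in compound 2

A few compounds are considered here, and "the series" means these few. Any claim that something is new, unique, unknown or untested is made for them only; others in the source may bear on it.

Compound 1 `CC(=O)N1CCC(O)(C(=O)N2CC[C@](c3ccc(C(OCc4c(F)cccc4F)(C(F)(F)F)C(F)(F)F)cc3)(S(=O)(=O)c3ccc(F)cc3)C2)CC1` gives 69%
Compound 2 `O=C(O)[C@H]1CC[C@H](C(=O)N2CC[C@](c3ccc(C(OCc4ccccc4OC(F)(F)F)(C(F)(F)F)C(F)(F)F)cc3)(S(=O)(=O)c3ccc(F)cc3)C2)CC1` gives 81%

In an ADME assay on microsomes from liver (Mus musculus) for metabolic stability, with a stated time of 10 min (a higher number here means that more of the compound is left, a lower number that less of the compound is left), compound 2 stands highest of the two measured compounds at 81% and compound 1 lies lower at 69% with a gap beyond the usual scatter. These two compounds differ in more than one place, so their gap cannot be tied to any single structural feature.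

Compound 3 `O=C(O)[C@H]1CC[C@H](C(=O)N2CC[C@](c3ccc(C(OCC4CC4)(C(F)(F)F)C(F)(F)F)cc3)(S(=O)(=O)c3ccc(F)cc3)C2)CC1` has not yet been measured. The change from compound 2 is cyclopropyl in place of 2-(trifluoromethoxy)phenyl on a saturated chain carbon bound to an oxygen on a saturated carbon and it sits on a saturated chain carbon bound to an oxygen on a saturated carbon. Cut one bond further out, the same difference reads 2-(trifluoromethoxy)benzyl to cyclopropylmethyl.

Among the measured compounds shown here, no measured pair isolates this change, so the expectation rests on compound 2 at 81% as the closest reference. In this assay a small downward step is expected, one that stays within the scatter. The estimated step runs a number 3 percentage points lower from compound 2 to compound 3 (within the scatter) in this reading. Compound 3 is expected to give 78% with an estimated range from 60% to 92% as its span.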

Compound 3, percent of the compound remaining: 44%
For compound 3 the middle estimate is 34 percentage points above the measured one; measured number outside the range, below it.
By their numbers in this assay, from the lowest: compound 3; then compound 1; then compound 2.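

In this assay, the change of 2-(trifluoromethoxy)benzyl to cyclopropylmethyl gives a number 37 percentage points lower from compound 2 to compound 3 (beyond the scatter), the first difference in this series that can be tied to a single place. The two earlier compounds differ in more than one place, so they could not show that the group on a saturated chain carbon bound to an oxygen on a saturated carbon matters for this read-out; this step shows that it does, with everything else in compound 2 held constant. Nothing available bears on the reason for this step.

This single exchange removes the aromatic ring and the trifluoromethoxy group together, so the compounds shown leave open which of these the step follows, and whether an unsubstituted benzyl or a longer chain such as n-butyl at this place would give a value closer to that of compound 2 or that of compound 3. They also leave open whether the same exchange would give a step of similar size in a compound that lacks the carboxylic acid of compound 2.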